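A few compounds are considered here, and "the series" means these few. Any claim that something is new, unique, unknown or untested is made for them only; others in the source may bear on it.

Compound 3, whose structure is `COc1cc(/C=C/C(=O)Nc2ccccc2)ccc1OCCCCCCN1CCCCC1`, sits at the top of the three numbers measured in a physicochemical assay for lipophilicity, using the shake flask method, measured as octanol-water partition, at pH 7.4; on this read-out higher numbers stand for higher lipophilicity and lower numbers for lower lipophilicity: compound 3 gives 1.77, while compound 1 `COc1cc(/C=C/C(=O)Nc2ccccc2)ccc1OCCCN1CCCCC1` gives 1.58 and compound 2 `COc1cc(/C=C/C(=O)Nc2ccccc2)ccc1OCCCN1CCCC1` gives 1.57. All three lie within the scatter of one another, so no order among them can be read from these numbers.

Compound 4, with the structure `COc1cc(/C=C/C(=O)Nc2ccccc2)ccc1OCCCCCCCCN(C)C`, carries the change (2-(dimethylamino)ethyl in place of piperidin-1-yl on a saturated chain carbon, six bonds along the chain from an oxygen on an aromatic ring). The measured steps offer only loose guidance. Swapping one ring for another, as from compound 1 to compound 2, gave a number 0.01 log units lower from compound 1 to compound 2 (within the scatter); lengthening the chain gave a number 0.19 log units higher from compound 1 to compound 3 (within the scatter) and a number 0.20 log units higher from compound 2 to compound 3 (within the scatter). Within the data shown here, none of these opens the ring or moves the nitrogen further out, so no measured step matches the present change directly. Every change seen so far stayed within the scatter, and the step to compound 4 is expected to do the same, roughly a number 0.02 log units lower from compound 3 to compound 4 (within the scatter). Compound 4 is therefore expected to read about 1.75 in this assay, between 1.35 and 2.15.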

Compound 4, partition coefficient: 1.74
Beside the measured number, compound 4's estimate is 0.01 log units above it; the measured number falls inside the stated range.
By their numbers in this assay, from the lowest: compounds 2, 1, 4 and 3 (each within the scatter of the next).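

In this assay, among these compounds, 2-(dimethylamino)ethyl in place of piperidin-1-yl, six bonds along the chain from an oxygen on an aromatic ring, gives a number 0.03 log units lower from compound 3 to compound 4 (within the scatter) and so shows that losing the ring at the chain end leaves the reading within the scatter, a change the earlier steps, which all kept a ring there, could not show. Counted from the position three bonds along the chain, 5-(dimethylamino)pentyl gives a number 0.17 log units higher from compound 2 to compound 4 (within the scatter) in place of pyrrolidin-1-yl and a number 0.16 log units higher from compound 1 to compound 4 (within the scatter) in place of piperidin-1-yl, so a longer chain and an open end together also stay within the scatter. No outside evidence bears on this result.

From the compounds shown here alone, what stays open is whether any chain end moves this reading beyond the scatter, for example a carboxylic acid in place of the amine, or a much longer chain.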